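A few compounds are considered here, and "the series" means these few. Any claim that something is new, unique, unknown or untested is made for them only; others in the source may bear on it.

Three compounds have been measured in a toxicity assay on THP-1 cells (Homo sapiens) for inhibition; a lower number here means that less compound is tolerated, a higher number that more compound is tolerated:
compound 1 `COc1ccc(-c2cnc(NC(=O)CCc3ccccc3)n2C)cc1`, > 100000 nM;
compound 2 `COc1ccc(-c2noc(NC(=O)c3ccc(F)cc3)c2C)cc1`, > 100000 nM;
compound 3 `Cc1ccc(C(=O)Nc2ncc(-c3ccccc3)n2C)cc1`, > 50000 nM.

The value of compound 1 is a limit of the assay and not a number; it sits at the limit of > 100000 nM in this assay, at which 2 of the 3 values shown sit. Compound 2 likewise reaches only a limit. Compound 3 also stands at a limit, (the limit of > 50000 nM in this assay, at which 1 of the 3 values shown sits). So compound 1 stands where every measured compound stands: at a limit, with no measured number. Compound 4 `COc1ccc(-c2cnc(NC(=O)C3CCOCC3)n2C)cc1` differs from compound 1 in one place: oxan-4-yl in place of phenethyl on a carbonyl carbon. Among the compounds with values here, no step between measured compounds is known, and none of the three shows toxicity within the tested range. The change is therefore expected to bring no step beyond the scatter, with a number no higher from compound 1 to compound 4 (the limit leaves the size open). Compound 4 is estimated at 100000 nM, between 50000 nM and 200000 nM.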

Compound 4, half-maximal cytotoxic concentration: > 100000 nM
Compound 4 was reported as a limit; the forecaster's own chance of this, stated with the estimate: 85%; the middle value lies on the limit itself.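

Within the data shown here, compound 1 and compound 4 both stand at a limit and not at a number, so no step between them can be read. The compounds shown leave open at what concentration, if any, each would become toxic in this assay.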